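Compound 3 to compound 4: hydroxy to sulfooxy

The compounds below may be only part of what the source reports. "The series", "measured", "known", "first", "only" and "open" are said of these compounds alone.

Compound 1 `COc1ccc(/C=C/c2cc(SC)nc(N)n2)cc1`: 250000 nM
Compound 2 `CSc1cc(/C=C/c2ccc(OC3CCCCO3)cc2)nc(N)n1`: 122000 nM
Compound 3 `CSc1cc(/C=C/c2ccc(O)cc2)nc(N)n1`: "not determined" (no result reported)

In an ADME assay on Vero cells (Chlorocebus sabaeus) for cytotoxicity, read by MTT assay, with a stated time of 72 h (on this read-out higher numbers stand for lower toxicity in this test and lower numbers for higher toxicity in this test), compound 3 offers no number to start from: "not determined" (no result reported). Compound 4 `CSc1cc(/C=C/c2ccc(OS(=O)(=O)O)cc2)nc(N)n1` differs from it in one place: sulfo in place of hydrogen on an oxygen on an aromatic ring. That is sulfo in place of hydrogen on an oxygen on an aromatic ring. Within the data shown here, the only measured step that changes a group on such an oxygen is modest, oxan-2-yl in place of methyl: a 2.0-fold lower number from compound 1 to compound 2 (0.31 log units; beyond the scatter). Among the measured compounds shown here, no measured step involves sulfo, and compound 3 has no value, so neither the size nor the direction of a step can be expected. Only a placement in the same region as compound 1 and compound 2 is reasonable. Compound 4 is expected at about 180000 nM, with an estimated range of 70000 nM to 450000 nM.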

Compound 4, half-maximal cytotoxic concentration: 301000 nM
Compound 4: the middle estimate sits 1.7-fold (0.22 log units) below what was measured; the measured number falls inside the stated range.
By their numbers in this assay, from the lowest: compound 2; then compounds 1 and 4 (each within the scatter of the next).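

On the oxygen on the aromatic ring, sulfo now stands alongside methyl and oxan-2-yl, and this assay shows a 1.2-fold higher number from compound 1 to compound 4 (0.08 log units; within the scatter) and so does not separate sulfo from methyl. Against oxan-2-yl it shows a 2.5-fold higher number from compound 2 to compound 4 (0.39 log units; beyond the scatter) and this leaves compound 2 with the lowest number of the three, though these quite different groups span only a modest range. Compound 3 has no number, so its step to compound 4 cannot be read. From the compounds shown here alone, how a carboxylic acid or a longer chain on this oxygen would read stays open. No measurement here explains these steps.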